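The compounds below may be only part of what the source reports. "The series", "measured", "known", "first", "only" and "open" are said of these compounds alone.

Compound 3, `CC1=C(C(=O)Nc2ccc(Br)cc2)C(c2ccc(Cl)cc2Cl)N=C(SCc2ccc(F)cc2)N1`, gives in a functional assay on the whole organism (artery, strain albino) with Rattus norvegicus as the target, with a stated time of 120 min, at a dose of 10 mg/kg by the oral route (on this read-out higher numbers stand for more inhibition at the one dose given (going by the name of the read-out) and lower numbers for less inhibition), a value of 22.7%, the top of the three numbers recorded. Compound 2, `CC1=C(C(=O)Nc2ccc(Br)cc2)C(c2ccc(Cl)cc2Cl)N=C(SCc2ccc(Cl)cc2)N1`, gives 17.5%, a difference that lies within the scatter, while compound 1, `CC1=C(C(=O)Nc2ccc(F)cc2)C(c2ccc([N+](=O)[O-])cc2)N=C(SCc2cccc(Cl)c2)N1`, gives 9.8%, beyond it. Compound 4, `COc1ccc(C2N=C(SCc3ccc(F)cc3)NC(C)=C2C(=O)Nc2ccc(Br)cc2)cc1`, differs from compound 3 in one place: 4-methoxyphenyl in place of 2,4-dichlorophenyl on a saturated ring carbon. Within the data shown here, the only measured step, a number 5.2 percentage points higher from compound 2 to compound 3 (within the scatter), concerns the fluoro-for-chloro swap on the benzyl ring, a different place, and was within the scatter. Among the measured compounds shown here, no measured step touches the saturated ring carbon, so the expectation for compound 4 rests on little. Compound 4 is estimated at 18%, from 5% to 32%, a step of a number 4.7 percentage points lower from compound 3 to compound 4 (within the scatter) that is expected to stay within the scatter.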

Compound 4, a percentage reported as inhibition, in the whole organism at one dose (the size of the read-out at that dose, not a potency): 12.9%
For compound 4 the middle estimate is 5.1 percentage points above the measured one; low and high end bracket the measured number.
By their numbers in this assay, from the lowest: compounds 1, 4, 2 and 3 (each within the scatter of the next, the first and the last beyond it).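

In this assay, the saturated ring carbon now has its first measured change: 4-methoxyphenyl in place of 2,4-dichlorophenyl gives a number 9.8 percentage points lower from compound 3 to compound 4 (within the scatter). This one pair does not separate the two groups, so neither can be ranked above the other at this position. Nothing shown here bears on why the step has this size. Still open, going by these compounds, is whether a plain phenyl, or a phenyl carrying an amine or a carboxylic acid, at this ring carbon would give a step beyond the scatter.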